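Removing a Methyl from the Pyridine of Compound 2

A few compounds are considered here, and "the series" means these few. Any claim that something is new, unique, unknown or untested is made for them only; others in the source may bear on it.

Measured compounds:
Compound 1 `Cc1ccc(-c2nn(-c3ccccc3)cc2-c2nc3ccccc3n2C(=O)c2ccc(Cl)cc2)cc1` gives 216000 nM
Compound 2 `Cc1cncc(C(=O)n2c(-c3cn(-c4ccccc4)nc3-c3ccc(C(F)(F)F)cc3)nc3ccccc32)c1` gives 123000 nM

Both values come from an ADME assay on HEK-293T cells (Homo sapiens) for cytotoxicity, read by MTT assay, with a stated time of 24 h; on this read-out lower numbers stand for higher toxicity in this test and higher numbers for lower toxicity in this test. Compound 2 has the lowest of the two numbers, but compound 1 lies within the scatter of it, so the two cannot be told apart. Compound 3 `O=C(c1cccnc1)n1c(-c2cn(-c3ccccc3)nc2-c2ccc(C(F)(F)F)cc2)nc2ccccc21` is not yet measured. It differs from compound 2 in one place: hydrogen in place of methyl on an aromatic carbon. Among the measured compounds shown here, no measured pair shows what such a change does here. The step from compound 2 to compound 3 is expected to be a 1.2-fold higher number from compound 2 to compound 3 (0.09 log units; within the scatter), which is no change beyond the scatter. Compound 3 is therefore estimated at 150000 nM, between 60000 nM and 350000 nM.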

Compound 3, half-maximal cytotoxic concentration: 158000 nM
Compound 3: the middle estimate sits 1.1-fold (0.02 log units) below what was measured; low and high end bracket the measured number.
By their numbers in this assay, from the lowest: compounds 2, 3 and 1 (each within the scatter of the next).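

In this assay, among the compounds shown here, replacing 5-methylpyridin-3-yl with pyridin-3-yl gives a 1.3-fold higher number from compound 2 to compound 3 (0.11 log units; within the scatter) and so gives the first direct reading of this change. At this position on the ring, the methyl can be swapped for hydrogen without a difference this test can separate from its usual scatter. Nothing available here explains this result. 

As far as these compounds go, only methyl and hydrogen are compared at this position, so the effect of an amine, a carboxylic acid or a longer chain on the same aromatic carbon remains open.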